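The source may report more compounds than this note shows. Statements on the series, on what has been measured and on what is new or still open speak of the compounds shown alone.

Measured so far in an ADME assay on L1210/0 cells (Mus musculus) for cytotoxicity, with a stated time of 48 h; a higher number here means a weaker inhibitor, a lower number a stronger inhibitor:
- compound 1, `O[C@H]1C[C@@H](Cn2cnc3c(Cl)ncnc32)c2ccccc21`: > 200000 nM
- compound 2, `O=C(CI)NCc1cn([C@H]2C[C@H](O)[C@@H](CO)O2)c(=O)[nH]c1=O`: 107000 nM

Among the compounds with values here, compound 2 is the only compound of the pair with a number in this assay. Compound 1 gives only a limit of the assay, (the limit of > 200000 nM in this assay, at which 1 of the 2 values shown sits), so no ordered comparison between the two is possible beyond noting that compound 2 sits at a measured value while compound 1 does not.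

Compound 3, `CCCCCCc1cn([C@H]2C[C@H](O)[C@@H](CO)O2)c(=O)[nH]c1=O`, is the next compound of the series, not yet measured in this assay. Against compound 2 the change is pentyl in place of ((iodomethyl)carbonyl)amino on a saturated chain carbon bound to an aromatic carbon. Within the data shown here, no measured step of this kind exists, so the size and direction of the step have to be estimated rather than read off. The expectation is a step from compound 2 to compound 3 of a 1.4-fold higher number from compound 2 to compound 3 (0.15 log units; within the scatter), that is little beyond the usual scatter, if anything toward a weaker inhibitor, with a real chance that this assay reports only a limit for compound 3.

For compound 3 in this assay the estimate is 150000 nM, with a range from 40000 nM to 400000 nM.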

Compound 3, half-maximal inhibitory concentration: > 200000 nM
Compound 3 was reported as a limit (the forecaster's own chance of this, stated with the estimate: 40%); middle value at least 1.3-fold (0.12 log units) away from the limit.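

In this assay compound 3 gives > 200000 nM, which is a limit of the assay and not a number. On a saturated chain carbon bound to an aromatic carbon, pentyl in place of ((iodomethyl)carbonyl)amino gives an at least 1.8-fold higher number from compound 2 to compound 3 (0.27 log units; that floor lies within the scatter). Within the data shown here, this is the first step read at this place, but it is only a floor, so it does not separate the two compounds and leaves the true size of the change unknown. Compound 2 therefore remains the only compound of the series with a number, and the other readings rest on the same limit: the limit of > 200000 nM in this assay, at which 2 of the 3 values shown sit.

On these data alone, it remains open whether the ((iodomethyl)carbonyl)amino group itself accounts for the measured value of compound 2, which a chloromethyl or plain methyl carbonyl amide at the same place would test. Also open, as far as these compounds go, is how a primary amine, a carboxylic acid or a longer chain than pentyl would read at this place, and whether any of them would give a number rather than a limit.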